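This account rests on a few compounds, and the source may have more. Where it says the series, first, only, none or still open, it means among the compounds named here.

Compound 1 `Cc1cccc(N2CCN(C3CN4CCC3CC4)C2=O)c1` is the benchmark of this small set: in a functional assay (Cavia porcellus) for antagonist activity at Serotonin 3 (5-HT3) receptor (Homo sapiens) (a higher number here means a weaker inhibitor, a lower number a stronger inhibitor), compound 1 gives 12 nM. Compound 2 `O=C1N(c2ccccc2)CCN1C1CN2CCC1CC2` carries the same core without its methyl, and in this assay compound 2 gives 2100 nM. The change between them is hydrogen in place of methyl on an aromatic carbon and it produced a 180-fold higher number from compound 1 to compound 2 (2.24 log units; beyond the scatter). Compound 3 `Cc1[nH]cnc1CN1CCN(c2ccccc2)C1=O` rests on a different core, and the difference between the two cores is not broken down here; in this assay compound 3 gives 26.9 nM, which places it between the other two.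

Compound 4 `O=C1N(Cc2c[nH]cn2)CCN1c1ccccc1` has not been measured. It relates to compound 3 by hydrogen in place of methyl on an aromatic carbon. Among the compounds with values here, this is the same kind of change as the one from compound 1 to compound 2, but not the same: there the methyl left a six-membered aromatic ring of carbon only, meta to a large group, whereas here it leaves a five-membered aromatic ring with 2 nitrogen, next to the ring nitrogen and next to the ring atom that bears a large group. Within the data shown here, on the strength of the single precedent, the loss of methyl is expected to weaken compound 4 relative to compound 3, though the different surroundings of the methyl make a smaller step than a 180-fold higher number from compound 1 to compound 2 (2.24 log units; beyond the scatter) seem plausible; the step is therefore expected to be a 9.3-fold higher number from compound 3 to compound 4 (0.97 log units; beyond the scatter). Compound 4 is expected to give about 250 nM in this assay, with a plausible range from 60 nM to 1500 nM.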

Compound 4, antagonist equilibrium constant: 45.4 nM
Compound 4: the middle estimate sits 5.5-fold (0.74 log units) above what was measured; the measured number lies below the stated range.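

Exchanging 5-methyl-1H-imidazol-4-yl for 1H-imidazol-4-yl gives a 1.7-fold higher number from compound 3 to compound 4 (0.23 log units; within the scatter) in this assay, so the two compounds of this pair cannot be told apart there. The change that counted for so much on the other core therefore does not carry over with its size, and in this series the name of the change alone does not fix its outcome, because the two steps differ by more than repeated measurements would allow: the same change on two cores in this assay, a 180-fold higher number (2.24 log units; beyond the scatter) from compound 1 to compound 2 and a 1.7-fold higher number (0.23 log units; within the scatter) from compound 3 to compound 4, 100-fold (2.02 log units) apart, beyond the scatter of two such steps What this does not show is which difference between the two pairs sets the gap, since the kind of ring that carries the methyl, the place of the methyl on that ring and the rest of the core all vary together, and one pair on each core cannot separate them.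

The compounds shown leave open whether an ethyl group or a chlorine atom in the place of the methyl would follow the same divide between the two cores. They also leave open how the methyl would behave at a second place on either core, and whether a third core would side with the large step or the small one.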